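Chain Lengthening on a Succinate Ester and Cytotoxicity

A few compounds are considered here, and "the series" means these few. Any claim that something is new, unique, unknown or untested is made for them only; others in the source may bear on it.

Compound 1, `CCCCOC(=O)CCC(=O)N1CCN(CCCOc2cc3c(Nc4ccc(F)c(Cl)c4)ncnc3cc2OC)CC1`: 94.4%
Compound 2, `CCCCCCCCOC(=O)CCC(=O)N1CCN(CCCOc2cc3c(Nc4ccc(F)c(Cl)c4)ncnc3cc2OC)CC1`: 87.3%

Both measured compounds were examined in a functional assay on A549 cells (Homo sapiens) for cytotoxicity, read by MTT assay, with a stated time of 24 h, tested at 10 uM; a lower number here means a stronger effect, a higher number a weaker effect of the compound at the concentration tested. Compound 1 `CCCCOC(=O)CCC(=O)N1CCN(CCCOc2cc3c(Nc4ccc(F)c(Cl)c4)ncnc3cc2OC)CC1` gives 94.4% there, and compound 2 `CCCCCCCCOC(=O)CCC(=O)N1CCN(CCCOc2cc3c(Nc4ccc(F)c(Cl)c4)ncnc3cc2OC)CC1` gives 87.3%. Compound 2 stands with compound 1 within the usual scatter of this assay: the step of a number 7.1 percentage points lower from compound 1 to compound 2 (within the scatter) is too small to separate the two, so neither compound can be called the more or the less active of the pair.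

Compound 3 `CCCCCCCCCOC(=O)CCC(=O)N1CCN(CCCOc2cc3c(Nc4ccc(F)c(Cl)c4)ncnc3cc2OC)CC1` has not yet been measured. It differs from compound 2 by methyl in place of hydrogen on a saturated chain carbon, eight bonds along the chain from an oxygen next to a carbonyl group, a further lengthening of the same ester chain. Among the compounds with values here, the only measured step that bears on this change is a number 7.1 percentage points lower from compound 1 to compound 2 (within the scatter), which added a longer piece to the same chain and still stayed within the scatter. A single added carbon on that chain is therefore expected to produce no step beyond the scatter, and the step of a number 2.3 percentage points lower from compound 2 to compound 3 (within the scatter) is estimated accordingly. For compound 3 the expected value in this assay is 85%, estimated to fall between 70% and 98%.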

Compound 3, a percentage reported as activity, at one concentration (the size of the read-out at that concentration, not a potency): 90%
Compound 3: middle estimate off by 5 percentage points, on the low side; the range from low to high includes it.
By their numbers in this assay, from the lowest: compounds 2, 3 and 1 (each within the scatter of the next).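

Methyl in place of hydrogen on a saturated chain carbon, eight bonds along the chain from an oxygen next to a carbonyl group, gives in this assay a number 2.7 percentage points higher from compound 2 to compound 3 (within the scatter), so this outer part of the ester chain now has a measured step of its own, and that step does not separate the two compounds. The whole difference in the ester chain, read as a single change, gives a number 4.4 percentage points lower from compound 1 to compound 3 (within the scatter), so all three steps among these compounds now stand within the scatter and the chain lengths shown do not set any one of them apart. No measurement at hand offers an explanation for these values.

The compounds shown leave open whether an amine or a carboxylic acid in place of this ester chain, or a longer chain than that of compound 3, would give a step beyond the scatter. They also leave open whether the three compounds would stay together at a higher concentration or after a longer exposure.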